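A few compounds are considered here, and "the series" means these few. Any claim that something is new, unique, unknown or untested is made for them only; others in the source may bear on it.

The measured compounds in a functional assay on BJAB cells (Homo sapiens) for antiproliferative activity, with a stated time of 4 days; a lower number here means that less compound is needed, a higher number that more compound is needed for the effect:

Compound 1, `CC(=O)Nc1ccc(-c2c(C)nn(-c3nc(-c4ccc(Cl)c(Cl)c4)c(SC(C)C)s3)c2C(=O)O)cc1`: 139000 nM
Compound 2, `Cc1c(-c2cc(Cl)cc(Cl)c2)c(C(=O)O)nn1-c1nc(-c2ccncc2)c(SC(C)C)s1`: "not active" (no number reported)
Compound 3, `Cc1nn(-c2nc(-c3ccc(Cl)c(Cl)c3)c(SC(C)C)s2)c(C(=O)O)c1-c1cc(C(F)(F)F)cc(C(F)(F)F)c1`: 1800 nM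

Three compounds share one core and differ in the aryl group on the five-membered ring. Compound 1 stands highest of the two compounds that gave a number in this assay; compound 3 lies far lower, well beyond the scatter, while compound 2 gave no number at all. The next compound, compound 4, `Cc1nn(-c2nc(-c3ccc(Cl)c(Cl)c3)c(SC(C)C)s2)c(C(=O)O)c1-c1ccccc1C(F)(F)F`, changes compound 1 in a single place: 2-(trifluoromethyl)phenyl in place of 4-acetamidophenyl on an aromatic carbon.

Among the measured compounds shown here, no measured pair shows this exact exchange, so the step is read from what the three compounds show. Compound 3, carrying a phenyl with two trifluoromethyl groups, gives 1800 nM, and compound 4 carries a phenyl with one trifluoromethyl group. A drop is therefore expected, larger than the scatter but smaller than the gap between compound 1 and compound 3. The expected step is a 12-fold lower number from compound 1 to compound 4 (1.06 log units; beyond the scatter). For compound 4 the estimate in this assay is 12000 nM, with a range from 2500 nM to 60000 nM.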

Compound 4, half-maximal effective concentration: 5200 nM
Compound 4: the middle estimate sits 2.3-fold (0.36 log units) above what was measured; measured number inside the range.
By their numbers in this assay, from the lowest: compound 3; then compound 4; then compound 1.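

Among the compounds shown here, this is the first exchange that changes only one place, so it shows that the aryl group on this aromatic carbon alone can move the result: in this assay, there is a 27-fold lower number from compound 1 to compound 4 (1.43 log units; beyond the scatter). The size of the group does not account for this in any simple way, as both groups have 10 heavy atoms and one six-membered aromatic ring of carbon only; the 4-acetamidophenyl carries a hydrogen-bond donor and acceptor, while the 2-(trifluoromethyl)phenyl carries neither. Nothing measured here explains the step.

The compounds shown do not separate the loss of the acetamide from the gain of the trifluoromethyl. A plain phenyl, or a phenyl bearing an amine or a nitrile, would help to tell these two apart.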